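This account rests on a few compounds, and the source may have more. Where it says the series, first, only, none or still open, it means among the compounds named here.

In an assay on HEK293 cells for inhibition of Ataxin-2 (Mus musculus), read by fluorescence and Amplex Red (a lower number here means a stronger inhibitor, a higher number a weaker inhibitor), the three measured compounds stand as follows: compound 1 `CC1(C)OB(c2ccc(COc3ccc(CNC(=O)[C@@H]4CCC(=O)N4Cc4ccccc4)cc3)cc2)OC1(C)C` gives 50 nM; compound 2 `CC1(C)OB(c2ccc(COc3ccc(CNC(=O)[C@H]4CCC(=O)N4Cc4ccccc4)cc3)cc2)OC1(C)C` gives 180 nM; compound 3 `O=C(O)c1ccc(COc2ccc(CNC(=O)[C@@H]3CCC(=O)N3Cc3ccccc3)cc2)cc1` gives 4500 nM.

Compound 3 carries the highest number of the three. The step of a 90-fold higher number from compound 1 to compound 3 (1.95 log units; beyond the scatter) is large, and the numbers of compound 2 and compound 3 show compound 3 as the higher of that pair as well.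

Compound 4 `O=C(O)c1ccc(COc2ccc(CNC(=O)[C@H]3CCC(=O)N3Cc3ccccc3)cc2)cc1` is the partner of compound 3 that differs as follows: the two compounds have the same atoms and bonds and differ only in configuration as drawn: 1 of 1 stereo elements differ; a stereocentre at a saturated ring carbon is drawn S in compound 3 and R in compound 4. Within the data shown here, one measured step bears on this change, because the fact that compounds 1 and 2 differ only in the configuration as drawn the same kind of inversion is seen there; that step, a 3.6-fold higher number from compound 1 to compound 2 (0.56 log units; beyond the scatter), was a modest rise. A rise of similar size in this assay is therefore expected: a 3.3-fold higher number from compound 3 to compound 4 (0.52 log units; beyond the scatter). Compound 4 is thus estimated at 15000 nM, with a range from 6000 nM to 40000 nM.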

Compound 4, half-maximal inhibitory concentration: > 5000 nM
Compound 4: no number, only a limit (the forecaster's own chance of this, stated with the estimate: 15%); the middle value does not contradict the limit.
By their numbers in this assay, from the lowest: compound 1; then compound 2; then compound 3. At a limit, above all of these: compound 4.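

In this assay compound 4 gives > 5000 nM, which is a limit and not a number. The inversion at the saturated ring carbon can therefore be read only as a floor, an at least 1.1-fold higher number from compound 3 to compound 4 (0.04 log units; that floor lies within the scatter), and this floor lies within the scatter, so it does not establish a rise in this pair. The exchange of the group of 9 heavy atoms for the carboxylic acid group also raises the number in the R configuration, an at least 27-fold higher number from compound 2 to compound 4 (1.44 log units; beyond the scatter).

From the compounds shown here alone, whether that exchange costs the same in both configurations stays open: the same change on two cores in this assay, a 90-fold higher number (1.95 log units; beyond the scatter) from compound 1 to compound 3 and an at least 27-fold higher number (1.44 log units; beyond the scatter) from compound 2 to compound 4; the limit leaves it open whether they differ How a nitrile or a primary amide would stand on that aromatic carbon is also open.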